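Swapping fluoro for chloro on the sulfonyl ring

This account rests on a few compounds, and the source may have more. Where it says the series, first, only, none or still open, it means among the compounds named here.

Three compounds have been measured in a functional assay on SMMC-7721 cells (Homo sapiens) for cytotoxicity, read by MTT assay, with a stated time of 24 h; on this read-out lower numbers stand for stronger inhibition and higher numbers for weaker inhibition:
compound 1 `O=C1/C(=C/c2cccnc2)CN(S(=O)(=O)c2ccc(F)cc2)C/C1=C\c1ccccc1F` gives 9900 nM;
compound 2 `O=C1/C(=C/c2cccnc2)CN(S(=O)(=O)c2ccc(Cl)cc2)C/C1=C\c1ccccc1F` gives 16100 nM;
compound 3 `O=C1/C(=C/c2cccnc2)CN(S(=O)(=O)c2ccc(F)cc2)C/C1=C\c1ccccc1C(F)(F)F` gives 6390 nM.

Compound 4 `O=C1/C(=C/c2cccnc2)CN(S(=O)(=O)c2ccc(Cl)cc2)C/C1=C\c1ccccc1C(F)(F)F` has not yet been measured. It differs from compound 3 by a single change, (chloro in place of fluoro on an aromatic carbon). The same change, (chloro in place of fluoro on an aromatic carbon), links compound 1 to compound 2, and there it produced a 1.6-fold higher number from compound 1 to compound 2 (0.21 log units; within the scatter), a step that stays within the usual scatter of repeated measurements. The two cores on which this change is made differ by trifluoromethyl in place of fluoro on an aromatic carbon, and that difference on its own gave a 1.5-fold lower number from compound 1 to compound 3 (0.19 log units; within the scatter), again within the scatter. Since the step of a 1.6-fold higher number from compound 1 to compound 2 (0.21 log units; within the scatter) was small, the same small move is expected for compound 4, estimated as a 1.6-fold higher number from compound 3 to compound 4 (0.19 log units; within the scatter). Compound 4 is therefore expected to come in at about 10000 nM, with a likely range from 5000 nM to 20000 nM. This expectation rests on just one measured pair, so the change could land somewhat differently on the core of compound 3 than it did on the core of compound 1.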

Compound 4, half-maximal inhibitory concentration: 4880 nM
Compound 4: the middle estimate sits 2.0-fold (0.31 log units) above what was measured; the whole stated range lies above it.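

In this assay, the swap from 4-fluorophenyl to 4-chlorophenyl on the sulfonyl group gave a 1.3-fold lower number from compound 3 to compound 4 (0.12 log units; within the scatter), a step as small as the one on the other core, and the two steps agree as closely as repeated measurements can show: the same change on two cores in this assay, a 1.6-fold higher number (0.21 log units; within the scatter) from compound 1 to compound 2 and a 1.3-fold lower number (0.12 log units; within the scatter) from compound 3 to compound 4, 2.1-fold (0.33 log units) apart, within the scatter of two such steps The trifluoromethyl change on the chloro-bearing core gave a 3.3-fold lower number from compound 2 to compound 4 (0.52 log units; beyond the scatter), which goes beyond the scatter, yet it cannot be told apart from the same change on the fluoro-bearing core: the same change on two cores in this assay, a 1.5-fold lower number (0.19 log units; within the scatter) from compound 1 to compound 3 and a 3.3-fold lower number (0.52 log units; beyond the scatter) from compound 2 to compound 4, 2.1-fold (0.33 log units) apart, within the scatter of two such steps So in this set of compounds, fluoro and chloro on the sulfonyl ring carry over as a change with little effect on either core, but one pair per core cannot show that the steps truly point in opposite directions, nor that the result would hold on any further core.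

These compounds leave open what a larger change in the same place would do, such as a methoxy group, a nitrile or an amine in place of the chloro. They also leave open whether the small size of this step would persist with a group other than fluoro or trifluoromethyl on the second aromatic ring, such as a bromo or a methyl group.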